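A few compounds are considered here, and "the series" means these few. Any claim that something is new, unique, unknown or untested is made for them only; others in the source may bear on it.

In a functional assay on TSGH cells (Homo sapiens) for inhibition, with a stated time of 72 h; a lower number here means a stronger inhibitor, a higher number a weaker inhibitor:
- compound 1 `COc1cc(C(=O)c2ccc3[nH]ccc3c2)cc(OC)c1OC`: 103 nM
- compound 2 `COc1cc(C(=O)c2ccc3c(ccn3C)c2)cc(OC)c1OC`: 13.4 nM
- compound 3 `CCCn1ccc2cc(C(=O)c3cc(OC)c(OC)c(OC)c3)ccc21`: not yet measured

Of the two measured compounds, compound 2 holds the lower number, at 13.4 nM. Compound 3 keeps the core of compound 2 and carries a longer group on the aromatic nitrogen: ethyl in place of hydrogen on a saturated chain carbon bound to an aromatic nitrogen, so methyl becomes propyl. For the measured compounds named here, only one measured step bears on this, a 7.7-fold lower number from compound 1 to compound 2 (0.89 log units; beyond the scatter), which lies beyond the scatter and came with methyl in place of hydrogen on an aromatic nitrogen. Going by the values given here, that step concerns the same nitrogen but is a different change, and no measured compound carries a longer chain there. A modest rise in this assay is therefore expected, though no change remains possible. The expected step is a 2.6-fold higher number from compound 2 to compound 3 (0.42 log units; beyond the scatter). Compound 3 is estimated at 35 nM, with an expected range of 10 nM to 130 nM.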

Compound 3, half-maximal inhibitory concentration: 1500 nM
For compound 3 the middle estimate is 43-fold (1.63 log units) below the measured one; measured number outside the range, above it.
By their numbers in this assay, from the lowest: compound 2; then compound 1; then compound 3.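

In this assay the aromatic nitrogen of the shared core tolerates far less than the first two compounds suggested: going from methyl to propyl gives a 110-fold higher number from compound 2 to compound 3 (2.05 log units; beyond the scatter) and so reverses the gain seen on going from hydrogen to methyl. The loss also carries past the compound with no group on that nitrogen, with a 15-fold higher number from compound 1 to compound 3 (1.16 log units; beyond the scatter) on adding propyl, so across these three compounds the number does not move in one direction as the chain grows. Nothing at hand explains this reversal.

The compounds shown leave open how an ethyl group on this nitrogen would fall, and so at what chain length the loss sets in. They also leave open whether a branched isopropyl group, or a propyl chain ending in an amine or a hydroxyl group, would fare any better than plain propyl.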